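A few compounds are considered here, and "the series" means these few. Any claim that something is new, unique, unknown or untested is made for them only; others in the source may bear on it.

The study concerns antagonists of the receptor examined in a functional assay on CHO cells for antagonist activity at sphingosine 1-phosphate receptor 2 (Homo sapiens), read by GTPgammaS binding; a higher number here means a weaker inhibitor, a lower number a stronger inhibitor. Compound 1 `CCOc1cc2[nH]c(Cc3nn(CC(=O)N4CCOCC4)c(=O)c4ccccc34)nc2cc1Cl` gives 22 nM in this assay and holds the lower of the two numbers recorded. Compound 2 `COc1ccc(Cl)cc1NC(=O)Cc1nn(CC(=O)O)c(=O)c2ccccc12`, built on a different core, gives 1190 nM in this assay, a far higher number than compound 1 shows and well beyond the scatter. Going by the values given here, because the two compounds differ in more than one place, their values show only that compound 2 is the weaker inhibitor of the pair.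

Compound 3 `CCOc1cc2[nH]c(Cc3nn(CC(=O)O)c(=O)c4ccccc34)nc2cc1Cl` has not yet been measured in this assay. It differs from compound 1 in a single place: hydroxy in place of morpholin-4-yl on a carbonyl carbon. Compound 2 also carries a carboxymethyl group, but on another core, so its value cannot simply be carried over. Among the compounds with values here, no measured pair reproduces this change, and the expectation therefore rests on the scale of the numbers in hand. The step from compound 1 to compound 3 is expected to be a modest loss of potency, a 2.7-fold higher number from compound 1 to compound 3 (0.44 log units; beyond the scatter), slightly beyond the scatter. Compound 3 is thus estimated at 60 nM in this assay, within a range of 15 nM to 300 nM.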

Compound 3, half-maximal inhibitory concentration in the sphingosine 1-phosphate receptor 2 assay: 109 nM
Estimate against measurement, compound 3: 1.8-fold (0.26 log units) below; the range from low to high includes it.
By their numbers in the sphingosine 1-phosphate receptor 2 assay, from the lowest: compound 1; then compound 3; then compound 2.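

Going by these compounds alone, this is the first step read at this position with the core held constant, and in the sphingosine 1-phosphate receptor 2 assay it is modest: a 5.0-fold higher number from compound 1 to compound 3 (0.70 log units; beyond the scatter), so compound 3, with its carboxy group, remains an inhibitor after losing the whole morpholin-4-yl ring. In a physicochemical assay for lipophilicity, at pH 7.4 (on this read-out higher numbers stand for higher lipophilicity and lower numbers for lower lipophilicity), compound 1 gives 3.32 and compound 3 gives 1.8. The single change from morpholin-4-yl to hydroxy on a carbonyl carbon thus pairs a modest loss of potency with a large fall in lipophilicity: the measured distribution coefficient of compound 1, 3.32, and of compound 3, 1.8, a number 1.52 log units lower (beyond the scatter)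

With one step at this position, the compounds shown do not tell whether the loss follows from removing the morpholin-4-yl ring or from introducing the hydroxy group, and a methoxy group or a piperidin-1-yl group on the same carbonyl carbon would be needed to separate the two. Also open, from the compounds shown here alone, is whether the carboxy group tolerates a longer chain than carboxymethyl, and whether the difference between these two compounds would recur on the core of compound 2.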